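Swapping an Aryl Cap for an Octyl Chain on a Triazole

The compounds below may be only part of what the source reports. "The series", "measured", "known", "first", "only" and "open" are said of these compounds alone.

The series is built on one shared core, and the compounds differ only in the group carried on an aromatic nitrogen of the five-membered ring. Compound 1 `CC1(C)CCc2cc(C(=O)/C=C/c3ccc(OCc4cn(-c5ccc(Cl)cc5)nn4)cc3)c(O)cc2O1` bears a 4-chlorophenyl there. In a functional assay on HepG2 cells (Homo sapiens) for antiproliferative activity, read by MTT assay (a higher number here means a weaker inhibitor, a lower number a stronger inhibitor), compound 1 is reported as "not active" (no number reported), so no single number places it on the scale. Compound 2 `CCc1ccccc1-n1cc(COc2ccc(/C=C/C(=O)c3ccc4c(c3O)CCC(C)(C)O4)cc2)nn1` carries a different aryl group on the same nitrogen, and in this assay compound 2 gives 67800 nM, a very weak result. Among the compounds with values here, no step between these two measured compounds can be computed, since compound 1 has no number to compare.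

Compound 3 `CCCCCCCCn1cc(COc2ccc(/C=C/C(=O)c3cc4c(cc3O)OC(C)(C)CC4)cc2)nn1` has not yet been measured in this assay. Its difference from compound 1 is octyl in place of 4-chlorophenyl on an aromatic nitrogen. With compound 1 inactive and compound 2 very weak, the expected step from compound 1 to compound 3 in this assay is small or none beyond the scatter, and the chance that only a limit is reported is high. Compound 3 is expected to give about 70000 nM, within a range from 20000 nM to 250000 nM.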

Compound 3, half-maximal inhibitory concentration: 127000 nM
The estimate for compound 3 lay 1.8-fold (0.26 log units) below the measured number; the range from low to high includes it.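

In this assay, within the data shown here, compound 3 gives 127000 nM while compound 1 is reported as "not active" (no number reported) and so no step between compound 1 and compound 3 can be read. The compounds shown leave open how far octyl and 4-chlorophenyl on this nitrogen actually differ in this read-out. Nothing measured here offers an explanation of the result.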